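The source may hold more compounds than are shown below. What is called first, only, known or untested is meant among the compounds shown, and "the series" means these compounds.

Compound 1, `Fc1ccc(C(SCCNC2CCN(Cc3ccccc3)CC2)c2ccc(F)cc2)cc1`, gives 3.81 nM in an assay on membranes from Cortex for displacement of a labelled ligand from Sigma non-opioid intracellular receptor 1 (Cavia porcellus), read by scintillation counting, with a stated time of 120 min; on this read-out lower numbers stand for stronger inhibition and higher numbers for weaker inhibition.
Compound 2, `Fc1ccc(C(SCCNC2CCN(Cc3ccc(C(F)(F)F)cc3)CC2)c2ccc(F)cc2)cc1`, gives 186 nM in this assay.
Compound 3, `O=C(c1ccc(F)cc1)N1CCC(NCCSC(c2ccc(F)cc2)c2ccc(F)cc2)CC1`, gives 32.1 nM in this assay.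

Compound 3 stands second highest of the three numbers: compound 2 lies nearest, with a 5.8-fold lower number from compound 2 to compound 3 (0.76 log units; beyond the scatter), and compound 1 lies furthest, with an 8.4-fold higher number from compound 1 to compound 3 (0.93 log units; beyond the scatter). Compound 4, `Fc1ccc(C(SCCNC2CCN(Cc3cc4ccccc4[nH]3)CC2)c2ccc(F)cc2)cc1`, has not yet been measured in this assay. It differs from compound 3 in one place: (1H-indol-2-yl)methyl in place of (4-fluorophenyl)carbonyl on an amine nitrogen in a ring. Among the compounds with values here, two measured steps bear on this change. The step of an 8.4-fold higher number from compound 1 to compound 3 (0.93 log units; beyond the scatter) shows that replacing benzyl with (4-fluorophenyl)carbonyl on the ring nitrogen raised the number, and the step of a 49-fold higher number from compound 1 to compound 2 (1.69 log units; beyond the scatter) shows that trifluoromethyl on the benzyl raised it further. Compound 4 returns to a methylene-linked aromatic group on that nitrogen, as in compound 1, rather than a carbonyl. A lower number than that of compound 3 is therefore expected for compound 4, with a step of a 3.6-fold lower number from compound 3 to compound 4 (0.55 log units; beyond the scatter). The estimate for compound 4 in this assay is 9 nM, within a range from 2.5 nM to 40 nM.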

Compound 4, inhibition constant: 205 nM
Compound 4: the middle estimate sits 23-fold (1.36 log units) below what was measured; measured number outside the range, above it.
By their numbers in this assay, from the lowest: compound 1; then compound 3; then compounds 2 and 4 (each within the scatter of the next).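

In this assay, (1H-indol-2-yl)methyl in place of (4-fluorophenyl)carbonyl on the amine nitrogen in the ring gave a 6.4-fold higher number from compound 3 to compound 4 (0.81 log units; beyond the scatter), so a saturated chain carbon on that nitrogen does not by itself give a lower number than the carbonyl. With that carbon kept, 1H-indol-2-yl in place of phenyl gave a 54-fold higher number from compound 1 to compound 4 (1.73 log units; beyond the scatter), and in place of 4-(trifluoromethyl)phenyl it gave a 1.1-fold higher number from compound 2 to compound 4 (0.04 log units; within the scatter). Of the three aromatic groups on that carbon, only the phenyl of compound 1 gives a low number, while 1H-indol-2-yl and 4-(trifluoromethyl)phenyl do not.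

No measurement shown accounts for these steps. The compounds shown leave open whether the hydrogen-bond donor of 1H-indol-2-yl matters, as a methyl on its ring nitrogen would test, and whether a pyridine or a methoxyphenyl on the same carbon would give a number close to that of compound 1.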